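The source may report more compounds than this note shows. Statements on the series, on what has been measured and on what is new or still open speak of the compounds shown alone.

Measured in a functional assay on MCF7 cells (Homo sapiens) for cytotoxicity, read by MTT assay, with a stated time of 72 h; a lower number here means a stronger inhibitor, a higher number a weaker inhibitor:
- compound 1 `CNC(=O)c1cc(Oc2ccc(NC(=O)c3nccc(-c4ccc(OC)cc4)n3)cc2)ccn1`: 35200 nM
- compound 2 `CNC(=O)c1cc(Oc2ccc(NC(=O)c3cc(-c4ccc(C)cc4)ncn3)cc2)ccn1`: 34600 nM

Both numbers sit in the weak range, and the gap between compound 1 and compound 2 lies within the usual scatter of this assay, so no order can be read from the pair. Compound 2 is the point of departure for the next compound.

Compound 3 `CNC(=O)c1cc(Oc2ccc(NC(=O)c3cc(-c4ccccc4)ncn3)cc2)ccn1` differs from compound 2 in one place: hydrogen in place of methyl on an aromatic carbon. Within the data shown here, no measured pair isolates this change, so there is no observed step to lean on; what is known is only that the two measured compounds, with differently substituted aryl groups, read alike in this assay.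

The change is small in counted terms, and the expectation is for a step of no more than the scatter, if anything slightly toward a higher number. The estimated step of a 1.2-fold higher number from compound 2 to compound 3 (0.08 log units; within the scatter) is accordingly expected to stay within the scatter. Compound 3 is expected to give 42000 nM in this assay, with a range from 15000 nM to 120000 nM.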

Compound 3, half-maximal inhibitory concentration: 18200 nM
For compound 3 the middle estimate is 2.3-fold (0.36 log units) above the measured one; the measured number falls inside the stated range.
By their numbers in this assay, from the lowest: compounds 3, 2 and 1 (each within the scatter of the next).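

In this assay, among these compounds, this is the first pair that isolates the place para to a large group, and it gives a 1.9-fold lower number from compound 2 to compound 3 (0.28 log units; within the scatter) and so no readable difference between 4-methylphenyl and phenyl. On this core, then, the methyl group on that aromatic carbon can be exchanged for hydrogen without a step beyond the scatter, and both compounds remain in the weak range. Nothing at hand bears on a cause for this reading.

Only hydrogen and methyl are compared directly at this place, so the pair does not show how far the read-out can move there. From the compounds shown here alone, it remains open whether an amine, a carboxylic acid or a longer alkyl chain on that aromatic carbon would give a step beyond the scatter.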